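The compounds below may be only part of what the source reports. "The series", "measured", "known", "first", "only" and "open" are said of these compounds alone.

Compound 1 `CN1CCN(c2ccc3[nH]nc(S(=O)(=O)c4ccccc4Cl)c3c2)CC1`: 101 nM
Compound 2 `CC(C)Cn1nc(S(=O)(=O)c2cccc3ccccc23)c2cc(N3CCN(C)CC3)ccc21`: 1.4 nM
Compound 3 `CN1CCN(c2ccc3[nH]nc(S(=O)(=O)c4c(Cl)cccc4Cl)c3c2)CC1`: 40 nM

All three were measured in a functional assay on HeLa cells for antagonist activity at 5-hydroxytryptamine receptor 6 (Homo sapiens); a lower number here means a stronger inhibitor, a higher number a weaker inhibitor. Compound 3 gives the second highest of these three numbers; the nearest is compound 1, which in this assay gives 101 nM, and the furthest is compound 2, which in this assay gives 1.4 nM. Compound 4 `CN1CCN(c2ccc3[nH]nc(S(=O)(=O)c4ccc(Cl)cc4)c3c2)CC1` differs from compound 3 in one place: 4-chlorophenyl in place of 2,6-dichlorophenyl on a sulfonyl sulfur. Among the measured compounds shown here, the only measured step bearing on chlorine on this phenyl ring is a 2.5-fold lower number from compound 1 to compound 3 (0.40 log units; beyond the scatter), a modest gain. Compound 4 keeps a chlorine on the ring but not the arrangement seen in compound 3, so the step of a 2.0-fold higher number from compound 3 to compound 4 (0.30 log units; within the scatter) is expected to be small, most likely back toward the number of compound 1. Compound 4 is therefore estimated at 80 nM, with a range from 30 nM to 250 nM.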

Compound 4, half-maximal inhibitory concentration: 108 nM
Estimate against measurement, compound 4: 1.4-fold (0.13 log units) below; low and high end bracket the measured number.
By their numbers in this assay, from the lowest: compound 2; then compound 3; then compounds 1 and 4 (each within the scatter of the next).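

Moving the single chlorine, 4-chlorophenyl in place of 2-chlorophenyl on the sulfonyl sulfur, gives a 1.1-fold higher number from compound 1 to compound 4 (0.03 log units; within the scatter), so the two compounds cannot be told apart. Replacing 2,6-dichlorophenyl with 4-chlorophenyl gives a 2.7-fold higher number from compound 3 to compound 4 (0.43 log units; beyond the scatter), so among these three compounds only the 2,6-dichlorophenyl group stands apart, and by a modest margin. Nothing measured here explains this difference.

Still open, on these data alone, is whether a phenyl ring carrying two methyl groups or two fluorines in place of the chlorines, or carrying an amine, would match compound 3.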